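The source may report more compounds than this note shows. Statements on the series, on what has been measured and on what is new or still open speak of the compounds shown alone.

Compound 1 `CC1=CCC[C@H]2[C@](C)(CC3=C(O)C(=O)C=C(N)C3=O)[C@@H](C)CC[C@]12C` gives 18000 nM in a functional assay on HeLa cells (Homo sapiens) for cytotoxicity, read by MTT assay, with a stated time of 3 days; on this read-out lower numbers stand for stronger inhibition and higher numbers for weaker inhibition.
Compound 2 `CC1=CCC[C@H]2[C@](C)(CC3=C(O)C(=O)C=C(NCCC[S+](C)[O-])C3=O)[C@@H](C)CC[C@]12C` gives 16000 nM in this assay.

Compound 2 has the lower of these two numbers, but only just: the step of a 1.1-fold lower number from compound 1 to compound 2 (0.05 log units; within the scatter) lies within the usual scatter, so the two compounds cannot be told apart on this read-out. Compound 3 `CC1=CCC[C@H]2[C@](C)(CC3=C(O)C(=O)C=C(NCCC(C)C)C3=O)[C@@H](C)CC[C@]12C` differs from compound 2 by a group of 3 heavy atoms (3 carbon; no ring) in place of a group of 4 heavy atoms (2 carbon, 1 oxygen, 1 sulfur; no ring), on a saturated chain carbon, two bonds along the chain from an amine nitrogen.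

Going by the values given here, only one measured step bears on this change, the one that added the chain to the amine nitrogen, and it barely moved the number. Swapping the end of that chain is therefore expected to leave the read-out about where it is. Compound 3 is expected to give 16000 nM, between 6000 nM and 40000 nM. The expected step is no change at the digits printed from compound 2 to compound 3 (within the scatter), none beyond the scatter.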

Compound 3, half-maximal inhibitory concentration: 30000 nM
The estimate for compound 3 lay 1.9-fold (0.27 log units) below the measured number; low and high end bracket the measured number.
By their numbers in this assay, from the lowest: compounds 2, 1 and 3 (each within the scatter of the next).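

In this assay, the step of a 1.9-fold higher number from compound 2 to compound 3 (0.27 log units; within the scatter) shows that isopropyl can take the place of the sulfur-bearing chain end, with its hydrogen-bond acceptor, without a shift that stands out from the scatter. The step of a 1.7-fold higher number from compound 1 to compound 3 (0.22 log units; within the scatter) shows the same for isopentyl in place of hydrogen on the amine nitrogen, so neither chain can be told apart from the free amine on this read-out. Nothing measured here explains these numbers. The compounds shown leave open whether an amine or a carboxylic acid at the chain end, or a longer chain, would move the number beyond the scatter.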